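A few compounds are considered here, and "the series" means these few. Any claim that something is new, unique, unknown or untested is made for them only; others in the source may bear on it.

Compound 1 `O=C(CSC(=S)N[C@H]1CCOC1=O)Nc1ccc(F)cc1`: 67100 nM
Compound 2 `O=C(CCl)Nc1ccc(C(=O)/C=C/c2ccccc2)cc1`: 6370 nM
Compound 3 `O=C(CSC(=S)N[C@H]1CCOC1=O)Nc1ccc(C(=O)/C=C/c2ccccc2)cc1`: 44900 nM

These numbers come from a functional assay on EC9706 cells (Homo sapiens) for cytotoxicity, read by MTT assay, with a stated time of 72 h; on this read-out lower numbers stand for stronger inhibition and higher numbers for weaker inhibition. Compound 3 lies within the usual scatter of compound 1, and its number stands clearly higher than that of compound 2, as a 7.0-fold higher number from compound 2 to compound 3 (0.85 log units; beyond the scatter) shows. That step concerns a different part of the molecule, so it says little about what comes next.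

Compound 4 `O=C(CSC(=S)N[C@H]1CCOC1=O)Nc1ccc(C(=O)/C=C/c2cccc(Cl)c2)cc1` carries chloro in place of hydrogen on an aromatic carbon, turning phenyl into 3-chlorophenyl: chloro in place of hydrogen on an aromatic carbon. Going by the values given here, no measured step tests this change directly. The closest guide is a 1.5-fold lower number from compound 1 to compound 3 (0.17 log units; within the scatter), where bringing in the whole group that holds this phenyl left the number within the scatter. A single chlorine is a far smaller change, so no clear shift is expected. Among the compounds with values here, the expected result is a 1.2-fold lower number from compound 3 to compound 4 (0.07 log units; within the scatter), which would be no real step at all. In this assay, the estimate for compound 4 is 38000 nM, with an expected range of 15000 nM to 85000 nM.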

Compound 4, half-maximal inhibitory concentration: 32500 nM
Compound 4: the middle estimate sits 1.2-fold (0.07 log units) above what was measured; the range from low to high includes it.
By their numbers in this assay, from the lowest: compound 2; then compounds 4, 3 and 1 (each within the scatter of the next, the first and the last beyond it).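

Turning phenyl into 3-chlorophenyl gives a 1.4-fold lower number from compound 3 to compound 4 (0.14 log units; within the scatter) in this assay and is the first change shown on this ring itself, since the earlier steps swapped whole groups. It shows that a single chloro at this place on the aromatic ring leaves the number within the scatter, so the ring accepts this small addition without a clear gain or loss in cytotoxicity. Nothing measured here accounts for this result.

Still open, as far as these compounds go, is whether a different group at the same place, such as an amine, a carboxylic acid or a methoxy group, would move the number beyond the scatter. Also open, from the compounds shown here alone, is whether chloro would have a clear effect at another carbon of this ring, or on this ring in the chloroacetyl compound 2.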